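The source may hold more compounds than are shown below. What is called first, only, known or untested is meant among the compounds shown, and "the series" means these compounds.

Compound 1 `Cc1ccc(C)c(-c2ncnc3c2cnn3CCN2CCCCC2)c1`: 63 nM
Compound 2 `Cc1cncc(-c2ncnc3c2cnn3CCN2CCCCC2)c1`: 447 nM

Both were tested in an assay on HEK293 cells for displacement of a labelled ligand from Sigma non-opioid intracellular receptor 1 (Homo sapiens), read by scintillation counting, with a stated time of 120 min; a higher number here means a weaker inhibitor, a lower number a stronger inhibitor. Compound 2 gives the higher of the two numbers, a 7.1-fold higher number from compound 1 to compound 2 (0.85 log units; beyond the scatter). Compound 3 `Cn1cccc1-c1ncnc2c1cnn2CCN1CCCCC1` is still unmeasured; it differs from compound 2 by 1-methyl-1H-pyrrol-2-yl in place of 5-methylpyridin-3-yl on an aromatic carbon. For the measured compounds named here, the only measured step that bears on this is the one from compound 1 to compound 2, which also replaced the group on that aromatic carbon and shifted the number by a modest amount. A shift of similar size is expected here, with its direction uncertain; the expected step is a 2.5-fold lower number from compound 2 to compound 3 (0.40 log units; beyond the scatter). Compound 3 is therefore estimated at 180 nM, between 45 nM and 700 nM.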

Compound 3, inhibition constant: 31 nM
Estimate against measurement, compound 3: 5.8-fold (0.76 log units) above; measured number outside the range, below it.
By their numbers in this assay, from the lowest: compound 3; then compound 1; then compound 2.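

In this assay, swapping the group on this aromatic carbon for the five-membered 1-methyl-1H-pyrrol-2-yl gives a 14-fold lower number from compound 2 to compound 3 (1.16 log units; beyond the scatter) and a 2.0-fold lower number from compound 1 to compound 3 (0.31 log units; beyond the scatter). A six-membered aromatic ring is therefore not needed here, and compound 3 is the strongest inhibitor of the three. Nothing measured here accounts for these shifts.

The compounds shown leave open whether the methyl on the pyrrole nitrogen contributes to this result. They also leave open whether another five-membered ring, such as furan or thiophene, would give a similarly low number.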